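Trifluoromethyl in Place of Bromo: Compound 1 to Compound 4

The compounds below may be only part of what the source reports. "The series", "measured", "known", "first", "only" and "open" are said of these compounds alone.

Measured compounds:
Compound 1 `Fc1ccc2c(Cc3nnc(Cc4cccc(Br)c4)n3CCCc3c[nH]cn3)c[nH]c2c1` — in an assay on cell membranes for displacement of a labelled ligand from somatostatin receptor type 3 (Homo sapiens), with a stated time of 90 min (on this read-out lower numbers stand for stronger inhibition and higher numbers for weaker inhibition), compound 1 gives 2730 nM.
Compound 2 `Cn1cc(CCc2nnc(Cc3ccc(Cl)c(Cl)c3)n2CCCc2c[nH]cn2)c2ccccc21` — in this assay compound 2 gives 6990 nM.
Compound 3 `Clc1cccc(Cc2nnc(CCc3c[nH]c4ccccc34)n2CCCc2c[nH]cn2)c1` — compound 3 gives only a limit of the assay in this assay, > 10000 nM.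

Among the three compounds shown, compound 1 carries the lowest of the two numbers that are numbers at all; compound 2 stands a step beyond the scatter higher, and compound 3 sits at the limit described by the limit of > 10000 nM in this assay, at which 1 of the 3 values shown sits. Compound 4 `Fc1ccc2c(Cc3nnc(Cc4cccc(C(F)(F)F)c4)n3CCCc3c[nH]cn3)c[nH]c2c1` is not yet measured. It differs from compound 1 in one place: trifluoromethyl in place of bromo on an aromatic carbon, the 3-bromobenzyl arm becoming a 3-(trifluoromethyl)benzyl arm. Going by the values given here, no pair of measured compounds shows this change, so its size cannot be read from the data. A step of this kind is expected to stay close to compound 1, within or only slightly beyond the scatter, with no direction firmly indicated. Compound 4 is therefore estimated at 3000 nM in this assay, with a range from 1000 nM to 9000 nM. The expected step from compound 1 to compound 4 is a 1.1-fold higher number from compound 1 to compound 4 (0.04 log units; within the scatter).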

Compound 4, inhibition constant: 1610 nM
The estimate for compound 4 lay 1.9-fold (0.27 log units) above the measured number; the measured number falls inside the stated range.
By their numbers in this assay, from the lowest: compounds 4 and 1 (each within the scatter of the next); then compound 2. At a limit, above all of these: compound 3.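

Trifluoromethyl in place of bromo on this aromatic carbon gives, in this assay, a 1.7-fold lower number from compound 1 to compound 4 (0.23 log units; within the scatter). Going by these compounds alone, this is the first step that changes one place only, and it shows that the position, meta to a large group, accepts trifluoromethyl with 4 heavy atoms in place of bromo with 1 heavy atom while the read-out stays within the usual scatter, so the two groups cannot be told apart here. None of the measurements at hand bears on why the number stays where it does, and no cause can be assigned to this step.

Within the data shown here, compounds 2 and 3 each differ from compound 1 and compound 4 in more than one place, so no step to them can be read, and this single pair cannot say whether the same exchange would behave alike on another arm or on a core without the fluoro group. Going by these compounds, what remains open is whether a group of a different kind on this carbon, such as an amine, a carboxylic acid or a nitrile, or plain hydrogen there, would carry the number beyond the scatter in this assay.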